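A few compounds are considered here, and "the series" means these few. Any claim that something is new, unique, unknown or untested is made for them only; others in the source may bear on it.

Measured so far:
compound 1 `O=C(Nc1ccccc1)Nc1nnc(Sc2ncnc3scc(-c4ccncc4)c23)s1`: 19400 nM
compound 2 `Cc1ccc(NC(=O)Nc2nnc(Sc3ncnc4scc(-c5ccncc5)c34)s2)cc1`: 52000 nM
compound 3 `COc1cccc(NC(=O)Nc2nnc(Sc3ncnc4scc(-c5ccncc5)c34)s2)c1`: 28400 nM

In a functional assay on HepG2 cells (Homo sapiens) for antiproliferative activity, read by MTT assay, with a stated time of 48 h (on this read-out higher numbers stand for weaker inhibition and lower numbers for stronger inhibition), compound 2 gives the highest of these three numbers: next to it stands compound 3, then compound 1 at a greater distance, as a 2.7-fold higher number from compound 1 to compound 2 (0.43 log units; beyond the scatter) shows. Compound 4 `O=C(Nc1cccc(F)c1)Nc1nnc(Sc2ncnc3scc(-c4ccncc4)c23)s1` is not yet measured; it differs from compound 2 by 3-fluorophenyl in place of 4-methylphenyl on an amide-type nitrogen. The step that bears on it most closely is a 1.8-fold lower number from compound 2 to compound 3 (0.26 log units; within the scatter), where another group on the same ring replaced 4-methylphenyl and the number fell only within the scatter. The move from compound 1 to compound 2 shows that adding the methyl raised the number modestly. A similar modest lowering is therefore expected, a 2.0-fold lower number from compound 2 to compound 4 (0.30 log units; within the scatter). Compound 4 is estimated at 26000 nM (range 12000 nM to 56000 nM).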

Compound 4, half-maximal inhibitory concentration: 64100 nM
Estimate against measurement, compound 4: 2.5-fold (0.39 log units) below; measured number outside the range, above it.
By their numbers in this assay, from the lowest: compounds 1, 3, 2 and 4 (each within the scatter of the next, the first and the last beyond it).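

In this assay fluoro in place of hydrogen on the phenyl ring raises the number (a 3.3-fold higher number from compound 1 to compound 4 (0.52 log units; beyond the scatter)), so fluoro, like methyl, goes with weaker inhibition here. Fluoro in place of methoxy also separates two substituted rings (a 2.3-fold higher number from compound 3 to compound 4 (0.35 log units; beyond the scatter)), while 3-fluorophenyl in place of 4-methylphenyl does not (a 1.2-fold higher number from compound 2 to compound 4 (0.09 log units; within the scatter)). No measurement here explains these shifts. On these data alone, whether an amine or a carboxylic acid on this ring would bring the number below that of unsubstituted compound 1 stays open.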